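A few compounds are considered here, and "the series" means these few. Any claim that something is new, unique, unknown or untested is made for them only; others in the source may bear on it.

Measured so far:

Compound 1, `O=C(O)CCNC(=O)c1ccc(CN(c2ccc(Cl)cc2)c2nc(-c3ccc(C(F)(F)F)cc3)cs2)cc1`: 4.66 mL/min/kg
Compound 2, `O=C(O)CCNC(=O)c1ccc(CN(c2ccc(C(F)(F)F)cc2)c2nc(-c3ccc(Cl)cc3)cs2)cc1`: 2.23 mL/min/kg
Compound 3, `O=C(O)CCNC(=O)c1ccc(CN(c2ccc(OC(F)(F)F)cc2)c2nc(-c3ccc(C(F)(F)F)cc3)cs2)cc1`: 0.78 mL/min/kg

In an in vivo ADME assay on the whole organism (strain beagle) for pharmacokinetics, with Canis familiaris (Canis lupus familiaris) as the target (on this read-out higher numbers stand for fast clearance and lower numbers for slow clearance), compound 1 gives 4.66 mL/min/kg, the highest of the three numbers; the nearest is compound 2 and the furthest is compound 3, and the gap to each is beyond the scatter of the assay. For the measured compounds named here, the step to compound 3 is the only one-place change measured here: it reads a 6.0-fold lower number from compound 1 to compound 3 (0.78 log units; beyond the scatter).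

Compound 4, `O=C(O)CCNC(=O)c1ccc(CN(c2ccc(Cl)cc2)c2nc(-c3ccc(OC(F)(F)F)cc3)cs2)cc1`, keeps the chloro of compound 1 and instead changes the other end of the core: trifluoromethoxy in place of trifluoromethyl on an aromatic carbon. Going by the values given here, no measured step touches exactly this place. What bears on it is the step from compound 1 to compound 3, where the same trifluoromethoxy group entered, though on the other aromatic ring, and the number fell well beyond the scatter. Compound 2, which carries the two groups of compound 1 exchanged between the rings, also sits lower than compound 1. On that basis the number for compound 4 is expected to fall, as a 2.0-fold lower number from compound 1 to compound 4 (0.31 log units; beyond the scatter), though with less confidence than if the change sat in the measured place. The estimate for compound 4 in this assay is 2.3 mL/min/kg, with a range from 0.9 mL/min/kg to 6 mL/min/kg.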

Compound 4, clearance: 4.64 mL/min/kg
Beside the measured number, compound 4's estimate is 2.0-fold (0.30 log units) below it; the range from low to high includes it.
By their numbers in this assay, from the lowest: compound 3; then compound 2; then compounds 4 and 1 (each within the scatter of the next).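

In this assay, the step at the position para to a large group, a 1.0-fold lower number from compound 1 to compound 4 (0.00 log units; within the scatter), shows that trifluoromethoxy and trifluoromethyl cannot be told apart on this ring when the chloro on the other ring stays in place. The earlier step, a 6.0-fold lower number from compound 1 to compound 3 (0.78 log units; beyond the scatter), placed trifluoromethoxy on the other aromatic ring in place of chloro, so the same group goes with a clear difference in one place and none in the other, although these two steps also replace different groups. The data offer no measurement that could explain this contrast, so its cause remains unknown.

As far as these compounds go, the two groups compared at this position both contain carbon and fluorine, so it remains open whether a methoxy group, a nitrile or an amine there would also leave the number where compound 1 has it. From the compounds shown here alone, it is also open whether the same trifluoromethoxy for trifluoromethyl exchange would read the same way on a compound that does not carry the chloro, such as one with a methyl group or a nitrile on the other ring.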